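Working notes: phenyl to 2-chloro-4-nitrophenyl on the amide nitrogen

A few compounds are considered here, and "the series" means these few. Any claim that something is new, unique, unknown or untested is made for them only; others in the source may bear on it.

In an ADME assay on MT4 cells (Homo sapiens) for cytotoxicity, read by MTT assay (on this read-out higher numbers stand for lower toxicity in this test and lower numbers for higher toxicity in this test), compound 1 (`Cc1ccccc1NC(=O)CSc1nncnc1-c1cccc2ccccc12`) gives 158000 nM and compound 2 (`O=C(CSc1nncnc1-c1cccc2ccccc12)Nc1ccccc1`) gives 154000 nM, so compound 2 stands level with compound 1 within the scatter. Compound 3 (`O=C(CSc1nncnc1-c1cccc2ccccc12)Nc1ccc([N+](=O)[O-])cc1Cl`) carries 2-chloro-4-nitrophenyl in place of phenyl on an amide-type nitrogen. For the measured compounds named here, only one measured step bears on this change: a 1.0-fold lower number from compound 1 to compound 2 (0.01 log units; within the scatter), hydrogen in place of methyl on an aromatic carbon. That step lies within the scatter, but it exchanges far less than the present replacement, so it sets no firm size. Neither added group has been measured in this series. A moderate move to a lower number in this assay is therefore expected, with low confidence, as the estimated 2.2-fold lower number from compound 2 to compound 3 (0.34 log units; beyond the scatter). Compound 3 is expected at 70000 nM, with an estimated range of 18000 nM to 200000 nM.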

Compound 3, half-maximal cytotoxic concentration: 150000 nM
Compound 3: the middle estimate sits 2.1-fold (0.33 log units) below what was measured; the range from low to high includes it.
By their numbers in this assay, from the lowest: compounds 3, 2 and 1 (each within the scatter of the next).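

In this assay there is a 1.0-fold lower number from compound 2 to compound 3 (0.01 log units; within the scatter) when 2-chloro-4-nitrophenyl replaces phenyl on the amide-type nitrogen, and a 1.1-fold lower number from compound 1 to compound 3 (0.02 log units; within the scatter) when it replaces 2-methylphenyl. The earlier step covered only the loss of one methyl, whereas this replacement enters 10 heavy atoms for 6 and 2 hydrogen-bond acceptors for 0, and the values still stand level within the scatter. Nothing measured here offers an explanation for this flat result.

No change at this place in the compounds shown gives a step beyond the scatter, so what could move the read-out remains open. An amine, a carboxylic acid or a longer chain in place of the aryl group on the amide-type nitrogen would test whether this flat result extends beyond substituted phenyl groups.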